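Swapping trifluoromethyl for cyano on a shared pyrazole core

The source may hold more compounds than are shown below. What is called first, only, known or untested is meant among the compounds shown, and "the series" means these compounds.

Of the compounds shown here, three built on a shared core have been measured in an assay on isolated protein for inhibition of 2-Hydroxyacid oxidase 2 (Rattus norvegicus); on this read-out higher numbers stand for weaker inhibition and lower numbers for stronger inhibition. Compound 1 `Cc1n[nH]c(C(=O)O)c1Cc1cccc(-c2ccc(C#N)cc2)c1` gives 300 nM in this assay. Compound 2 `Cc1n[nH]c(C(=O)O)c1Cc1cccc(C(F)(F)F)c1` gives 300 nM. Compound 3 `Cc1n[nH]c(C(=O)O)c1Cc1cccc(-c2ccc(C(F)(F)F)cc2)c1` gives 400 nM. Compound 1 and compound 2 stand level at the digits printed, and compound 3 lies within the scatter of both, so no order among the three can be read from these numbers.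

One change has already been tried once. Compound 3 becomes compound 1 through (cyano in place of trifluoromethyl on an aromatic carbon), and this gave a 1.3-fold lower number from compound 3 to compound 1 (0.12 log units; within the scatter). The same kind of change turns compound 2 into the not yet measured compound 4 `Cc1n[nH]c(C(=O)O)c1Cc1cccc(C#N)c1`, namely (cyano in place of trifluoromethyl on an aromatic carbon); here the group sits meta to a large group, whereas in the earlier pair it sat para to a large group. The difference between the core of compound 2 and the core of compound 3 is not broken down here.

Since the earlier step stayed within the scatter, and since compound 1 and compound 2 stand level despite their different groups, a similarly small step is expected from compound 2 to compound 4 in this assay, estimated as a 1.2-fold higher number from compound 2 to compound 4 (0.07 log units; within the scatter). Compound 4 is therefore expected to give about 350 nM, with a likely range from 150 nM to 900 nM.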

Compound 4, half-maximal inhibitory concentration: 500 nM
Estimate against measurement, compound 4: 1.4-fold (0.15 log units) below, within the range that was stated.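

In this assay, placing cyano on the core of compound 2 in place of trifluoromethyl gave a 1.7-fold higher number from compound 2 to compound 4 (0.22 log units; within the scatter), and replacing the whole 4-cyanophenyl group with cyano gave a 1.7-fold higher number from compound 1 to compound 4 (0.22 log units; within the scatter). Neither step can be told apart from the ordinary variation between repeated measurements, so neither gives a firm ranking of these compounds. The comparison suggests that swapping trifluoromethyl for cyano has not produced a measurable difference between the two cores, but it does not prove that the swap carries over unchanged, as small real differences could be hidden within the scatter and there are only two pairs to compare: the same change on two cores in this assay, a 1.3-fold lower number (0.12 log units; within the scatter) from compound 3 to compound 1 and a 1.7-fold higher number (0.22 log units; within the scatter) from compound 2 to compound 4, 2.2-fold (0.35 log units) apart, within the scatter of two such steps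

The compounds leave open whether any replacement on this aromatic ring can move the result clearly beyond the scatter, as every step shown so far remains within it. An amine or a longer chain in the position held by cyano in compound 4 would test this, and would show whether the position responds to a group of another kind.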